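Removing One Methoxy Group: An Expected Small Step

A few compounds are considered here, and "the series" means these few. Any claim that something is new, unique, unknown or untested is made for them only; others in the source may bear on it.

Compound 1 `COc1ccc(-c2cc(/C=C/C(=O)c3ccc(N)cc3)[nH]n2)cc1` gives 4910 nM in a functional assay on CCRF-CEM cells (Homo sapiens) for inhibition, read by sulforhodamine B assay, with a stated time of 48 h; on this read-out lower numbers stand for stronger inhibition of growth and higher numbers for weaker inhibition of growth. Compound 2 `COc1cc(-c2cc(/C=C/C(=O)c3ccc(N)cc3)[nH]n2)cc(OC)c1OC` gives 4170 nM. Compound 3 `COc1cc(-c2cc(/C=C/C(=O)c3ccc(F)c(F)c3)[nH]n2)cc(OC)c1OC` gives 47200 nM.

Compound 2 has the lowest of the three numbers, but compound 1 stands within the scatter of it, so the two cannot be ranked; compound 3 lies far from both. Compound 4 `COc1ccc(-c2cc(/C=C/C(=O)c3ccc(N)cc3)[nH]n2)cc1OC` differs from compound 2 by hydrogen in place of methoxy on an aromatic carbon. For the measured compounds named here, no measured step touches this position. Going by the values given here, the only step, an 11-fold higher number from compound 2 to compound 3 (1.05 log units; beyond the scatter), changes the other ring and says nothing about methoxy count. The values of compound 1 and compound 2 show that going from one methoxy to three stayed within the scatter, and compound 4 sits between them. For compound 4 a step of a 1.1-fold higher number from compound 2 to compound 4 (0.03 log units; within the scatter) is therefore expected, none beyond the scatter. Compound 4 is estimated at 4500 nM, ranging from 1800 nM to 11000 nM.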

Compound 4, concentration for total growth inhibition: 7810 nM
Estimate against measurement, compound 4: 1.7-fold (0.24 log units) below, within the range that was stated.
By their numbers in this assay, from the lowest: compounds 2, 1 and 4 (each within the scatter of the next); then compound 3.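

This position now has measured steps of its own. In this assay, hydrogen in place of methoxy (a 1.9-fold higher number from compound 2 to compound 4 (0.27 log units; within the scatter)) and methoxy in place of hydrogen (a 1.6-fold higher number from compound 1 to compound 4 (0.20 log units; within the scatter)) both stay within the scatter, so compounds with one, two and three methoxy groups cannot be told apart here. Nothing measured speaks to why these numbers fall as they do.

Still open, on these data alone, is whether a different group at this position, such as ethoxy or a carboxylic acid, would move the number beyond the scatter. Also open, as far as these compounds go, is whether methoxy count matters when 3,4-difluorophenyl sits on the carbonyl carbon.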